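Imidazolyl for Pyrrolidinyl: an Expected Limit

The source may hold more compounds than are shown below. What is called first, only, known or untested is meant among the compounds shown, and "the series" means these compounds.

Measured compounds:
Compound 1, `COc1ccc(-c2c(Br)c(=O)c3c(OC)cc(OC)cc3n2S(=O)(=O)c2ccc(OC)cc2)cc1`: > 20000 nM
Compound 2, `COc1cc(OC)c2c(=O)cc(C(=O)Nc3cccc(N4CCCC4)c3)[nH]c2c1`: > 58600 nM

In a functional assay on HepG2 cells (Homo sapiens) for antiproliferative activity, with a stated time of 72 h (a higher number here means that more compound is needed for the effect, a lower number that less compound is needed), compound 1 reaches only a limit, > 20000 nM. Compound 2 likewise shows only a limit in this assay, > 58600 nM, so compound 2 stands at the limit of > 58600 nM in this assay, at which 1 of the 2 values shown sits, and no number is known for it. Compound 3, `COc1cc(OC)c2c(=O)cc(C(=O)Nc3cccc(-n4ccnc4)c3)[nH]c2c1`, differs from compound 2 by 1H-imidazol-1-yl in place of pyrrolidin-1-yl on an aromatic carbon. Going by the values given here, no measured step exists for such a change, and no shift beyond the scatter is expected; the step from compound 2 to compound 3 is estimated as a step that the limit leaves unreadable from compound 2 to compound 3. Compound 3 is therefore expected to give 60000 nM, within 20000 nM to 200000 nM, most likely again as a limit.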

Compound 3, half-maximal effective concentration: > 16300 nM
Compound 3 was reported as a limit (the forecaster's own chance of this, stated with the estimate: 80%); the middle value lies beyond the limit too.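

Compound 2 and compound 3 are both known only as limits in this assay, and the step between them cannot be read. The compounds shown leave open whether 1H-imidazol-1-yl in place of pyrrolidin-1-yl alters the effect at all.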